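This account rests on a few compounds, and the source may have more. Where it says the series, first, only, none or still open, it means among the compounds named here.

Among the measured compounds shown here, in an ADME assay on BEAS-2B cells (Homo sapiens) for cytotoxicity, read by MTT assay, with a stated time of 72 h (on this read-out lower numbers stand for stronger inhibition of growth and higher numbers for weaker inhibition of growth), compound 1, `CCCOC(=O)Nc1ccc([Se]C#N)cc1`, gives the highest of the three numbers measured so far, 19200 nM. Compound 2, `CCOC(=O)Nc1ccc([Se][Se]c2ccc(NC(=O)OCC)cc2)cc1`, gives 16100 nM, a number that lies within the scatter of that of compound 1. Compound 3, `CCCCCCOC(=O)Nc1ccc([Se][Se]c2ccc(NC(=O)OCCCCCC)cc2)cc1`, gives 10 nM, a far lower number, well beyond the scatter. Compound 4, `C=CCOC(=O)Nc1ccc([Se]C#N)cc1`, is not yet measured; it differs from compound 1 in one place: vinyl in place of ethyl on a saturated chain carbon bound to an oxygen next to a carbonyl group. For the measured compounds named here, no pair of measured compounds differs by this change alone, so nothing here anchors the size of the step; the expectation is a step no larger than the scatter, in no set direction. For compound 4 the estimated value is 19200 nM, with a range from 8000 nM to 45000 nM. The expected step from compound 1 to compound 4 is thus no change at the digits printed from compound 1 to compound 4 (within the scatter).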

Compound 4, concentration for 50% growth inhibition: 21400 nM
The estimate for compound 4 lay 1.1-fold (0.05 log units) below the measured number, and the stated range covers the measured number.
By their numbers in this assay, from the lowest: compound 3; then compounds 2, 1 and 4 (each within the scatter of the next).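

In this assay, vinyl in place of ethyl on a saturated chain carbon bound to an oxygen next to a carbonyl group gives a 1.1-fold higher number from compound 1 to compound 4 (0.05 log units; within the scatter) and so leaves the number within the scatter. This is the first pair shown that differs in one place only, and it shows that a double bond can sit at this position without a step that stands out from the scatter. Nothing shown bears on the reason for this result. As far as these compounds go, whether an amine or a carboxylic acid at this place would leave the number as unchanged remains open. So does whether this same change would give a similar step on another compound.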